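A few compounds are considered here, and "the series" means these few. Any claim that something is new, unique, unknown or untested is made for them only; others in the source may bear on it.

Compound 2 `CN1CCN(C(=S)SCc2ccc(C(=O)Nc3ccccc3N)cc2)CC1` stands highest of the two numbers measured in a functional assay on HeLa cells (Homo sapiens) for antiproliferative activity, read by CCK-8 assay, with a stated time of 72 h, tested at 2 uM (a higher number here means a stronger effect of the compound at the concentration tested, a lower number a weaker effect), where compound 2 gives 52.6%. Among the measured compounds shown here, its only comparator is compound 1 `Nc1ccccc1NC(=O)c1ccc(CSC(=S)N2CCc3ccccc32)cc1`, which in this assay gives 38%. For the measured compounds named here, the single measured step, a number 14.6 percentage points higher from compound 1 to compound 2 (beyond the scatter), swapped the group on the thiocarbonyl carbon and moved the number by a modest amount.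

Compound 3 `CN(Cc1ccncc1)C(=S)SCc1ccc(C(=O)Nc2ccccc2N)cc1` differs from compound 2 in the same place: methyl((pyridin-4-yl)methyl)amino in place of 4-methylpiperazin-1-yl on a thiocarbonyl carbon.

The step from compound 1 to compound 2 bears on this change only in that it concerns the same position, and it shows that exchanging the group there can shift the read-out by a modest amount beyond the scatter. Whether an open-chain amine with a pyridine will behave like the piperazine or like the indoline cannot be read from two compounds, so the direction is open. The step of a number 7.6 percentage points lower from compound 2 to compound 3 (within the scatter) is therefore expected to be small, and compound 3 is estimated to give 45% in this assay, within a range from 25% to 65%.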

Compound 3, a percentage reported as inhibition, at one concentration (the size of the read-out at that concentration, not a potency): 29.5%
Compound 3: the middle estimate sits 15.5 percentage points above what was measured; measured number inside the range.
By their numbers in this assay, from the lowest: compounds 3 and 1 (each within the scatter of the next); then compound 2.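

At this position, the group on the thiocarbonyl carbon can lower the read-out as well as raise it: in this assay, methyl((pyridin-4-yl)methyl)amino in place of 4-methylpiperazin-1-yl gives a number 23.1 percentage points lower from compound 2 to compound 3 (beyond the scatter) and removes the advantage of compound 2. Set against the 2,3-dihydro-1H-indol-1-yl group, the same open-chain group gives a number 8.5 percentage points lower from compound 1 to compound 3 (within the scatter) and so cannot be told apart from it here, which leaves compound 2 alone above two quite different groups. Among these three compounds, the 4-methylpiperazin-1-yl group is therefore the one that stands out, but no further data on these compounds help to explain the difference.

The compounds shown leave open which part of the 4-methylpiperazin-1-yl group matters, and a morpholin-4-yl or piperidin-1-yl group on the thiocarbonyl carbon would help to separate the ring from its methyl-bearing nitrogen. Going by these compounds, these numbers also come from one concentration in one cell line, so whether the compounds would show the same stronger and weaker effects at other concentrations, or in other cell lines, remains unknown.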